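A few compounds are considered here, and "the series" means these few. Any claim that something is new, unique, unknown or untested is made for them only; others in the source may bear on it.

Measured so far:
compound 1 `CCOC(=O)NS(=O)(=O)c1sc(CC(C)C)cc1-c1cccc(Cn2ccnc2)c1` — 300 nM
compound 2 `CC(C)Cc1cc(-c2cccc(Cn3ccnc3)c2)c(S(=O)(=O)NC(=O)OCC2CC2)s1` — 140 nM

Going by the values given here, in an assay on HEK293 cells for displacement of a labelled ligand from Type-2 angiotensin II receptor (Homo sapiens), read by scintillation counting, with a stated time of 240 min (a higher number here means a weaker inhibitor, a lower number a stronger inhibitor), compound 2 gives the lowest of the two numbers; its nearest neighbour is compound 1, and the single step of a 2.1-fold lower number from compound 1 to compound 2 (0.33 log units; beyond the scatter) enlarges the carbamate ester group. Compound 3 `CC(C)Cc1cc(-c2cccc(Cn3ccnc3)c2)c(S(=O)(=O)NC(=O)OC2CCCC2)s1` continues in that direction: cyclopentyl in place of cyclopropylmethyl on an oxygen next to a carbonyl group. Among the compounds with values here, only that one step bears on it, and it was modest, so the change to compound 3 is expected to be small: a 1.2-fold lower number from compound 2 to compound 3 (0.07 log units; within the scatter), with no clear grounds for a shift beyond the scatter. Compound 3 is therefore estimated at 120 nM in this assay, within 50 nM to 300 nM.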

Compound 3, inhibition constant: 180 nM
Beside the measured number, compound 3's estimate is 1.5-fold (0.18 log units) below it; low and high end bracket the measured number.
By their numbers in this assay, from the lowest: compounds 2, 3 and 1 (each within the scatter of the next, the first and the last beyond it).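

In this assay, a ring carried directly on the oxygen next to a carbonyl group is tolerated: a 1.3-fold higher number from compound 2 to compound 3 (0.11 log units; within the scatter) stays within the scatter, as does a 1.7-fold lower number from compound 1 to compound 3 (0.22 log units; within the scatter). Cyclopentyl therefore cannot be told apart from either cyclopropylmethyl or ethyl at this position, and the separation between compound 1 and compound 2 does not extend to a trend that includes compound 3. No supporting data offer an explanation for these readings.

Open, going by these compounds, is whether a phenyl ring, a longer chain or a terminal amine at this oxygen would shift the number beyond the scatter.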